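From Nitro to Fluoro in Compound 4

The source may hold more compounds than are shown below. What is called first, only, known or untested is meant among the compounds shown, and "the series" means these compounds.

compound 1 `N#C/C(=C\c1ccccc1OS(=O)(=O)c1ccc(F)cc1)C(=O)Nc1nnc(Cc2cccc(F)c2)s1` gives 17%
compound 2 `COc1ccc(S(=O)(=O)Oc2ccccc2/C=C(\C#N)C(=O)Nc2nnc(Cc3ccc(Cl)cc3)s2)cc1` gives 26%
compound 3 `N#C/C(=C\c1ccccc1OS(=O)(=O)c1ccc([N+](=O)[O-])cc1)C(=O)Nc1nnc(Cc2ccc(Cl)cc2)s1` gives 19%

In an ADME assay on HEK-293T cells (Homo sapiens) for inhibition, read by CCK-8 assay, with a stated time of 48 h, tested at 20 uM (a lower number here means less inhibition of growth, a higher number more inhibition of growth at the concentration tested), compound 3 stands at 19% and cannot be told apart from compound 1 at 17% or compound 2 at 26% on these numbers. All three lie within the usual scatter of one another.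

Compound 4 `N#C/C(=C\c1ccccc1OS(=O)(=O)c1ccc(F)cc1)C(=O)Nc1nnc(Cc2ccc(Cl)cc2)s1` differs from compound 3 at one place, where 4-nitrophenyl becomes 4-fluorophenyl. The change is fluoro in place of nitro on an aromatic carbon and it amounts to fluoro in place of nitro on an aromatic carbon, para to a large group.

Among the measured compounds shown here, no measured pair shows this exact swap, but two results bear on it. For the measured compounds named here, at the same place, the single measured step is a number 7 percentage points lower from compound 2 to compound 3 (within the scatter) and it came with nitro in place of methoxy. The 4-fluorophenyl group of compound 4 is already carried by compound 1, which differs from it elsewhere, and in this assay compound 1 gives 17% without standing apart from the others.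

On this evidence, no shift beyond the scatter is expected. The estimated change is a number 1 percentage points higher from compound 3 to compound 4 (within the scatter) and has no meaningful direction. Compound 4 is expected at 20% in a range from 10% to 31% on current evidence.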

Compound 4, percent growth inhibition at one concentration: 14%
The estimate for compound 4 lay 6 percentage points above the measured number; low and high end bracket the measured number.
By their numbers in this assay, from the lowest: compounds 4, 1, 3 and 2 (each within the scatter of the next, the first and the last beyond it).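

In this assay, fluoro in place of nitro gives a number 5 percentage points lower from compound 3 to compound 4 (within the scatter), so these two groups cannot be told apart at this position, and the change elsewhere in the molecule, 4-chlorophenyl in place of 3-fluorophenyl on the saturated chain carbon, is no clearer at a number 3 percentage points lower from compound 1 to compound 4 (within the scatter). What is new is a number 12 percentage points lower from compound 2 to compound 4 (beyond the scatter), a modest step and the only one at this aromatic carbon that lies beyond the scatter, while the nitro compound, compound 3, stays within the scatter of both of the others, so the methoxy and fluoro compounds separate without the three forming a clear series. Nothing available explains why the methoxy and fluoro compounds differ.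

The compounds shown leave open how an amine or a carboxylic acid would read on this same aromatic carbon, and whether the gap between methoxy and fluoro would persist with 3-fluorophenyl in place of 4-chlorophenyl on the chain carbon. With a single test concentration, they also leave open how growth inhibition changes at other concentrations.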